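The compounds below may be only part of what the source reports. "The series", "measured", "known", "first", "only" and "open" are said of these compounds alone.

Among the compounds with values here, the two compounds measured so far share one core and differ only in the group on the amide-type nitrogen. Compound 1, `O=C(NC1CCCC1)c1cc2ccccc2oc1=O`, gives 20% in an assay on HeLa cells for displacement of a labelled ligand from adenosine receptor A3 (Homo sapiens), read by scintillation counting, with a stated time of 180 min, tested at 10 uM; a higher number here means more inhibition at the concentration tested (going by the name of the read-out), a lower number less inhibition. Within the data shown here, compound 2, `O=C(NCCCO)c1cc2ccccc2oc1=O`, gives 6% in this assay, which is the lower of the two numbers; the single measured step between them, a number 14 percentage points lower from compound 1 to compound 2 (beyond the scatter), is the only step available in this set.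

Compound 3, `O=C(NCCCO)c1cc2cccc(O)c2oc1=O`, differs from compound 2 in one place: hydroxy in place of hydrogen on an aromatic carbon. Among the measured compounds shown here, this change sits on the fused ring system of the core, not on the amide-type nitrogen, so the step from compound 1 to compound 2 does not bear on it; no measured step in this set touches the aromatic ring at all. With nothing to lean on, the expected step of a number 2 percentage points higher from compound 2 to compound 3 (within the scatter) is none beyond the scatter, in either direction, and the uncertainty is wide. Compound 3 is therefore estimated to give 8% in this assay, within a range from -6% to 24%.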

Compound 3, a percentage reported as inhibition, at one concentration (the size of the read-out at that concentration, not a potency): 8%
Compound 3: middle estimate and measured number agree at the digits printed; low and high end bracket the measured number.
By their numbers in this assay, from the lowest: compounds 2 and 3 (each within the scatter of the next); then compound 1.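

Placing hydroxy in place of hydrogen on an aromatic carbon gives a number 2 percentage points higher from compound 2 to compound 3 (within the scatter) in this assay and so provides the first reading from the aromatic part of the shared core. Within the data shown here, with 3-hydroxypropyl on the amide-type nitrogen, this single added hydroxy does not separate compound 3 from compound 2 at the one concentration tested, while the earlier change on that nitrogen, a number 14 percentage points lower from compound 1 to compound 2 (beyond the scatter) in this assay, remains the only step here beyond the scatter. No measurement shown here offers an explanation for this result.

From the compounds shown here alone, it remains open whether a methoxy group, a chlorine atom or an amine on this same aromatic carbon would give a number beyond the scatter of compound 2, and whether hydroxy on another carbon of the ring would do so. Going by these compounds, it is also open whether the same hydroxy would give a similar step with cyclopentyl on the amide-type nitrogen, where compound 1 gives 20% in this assay without it, or with a longer chain ending in hydroxy in place of 3-hydroxypropyl.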